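The compounds below may be only part of what the source reports. "The series", "measured", "known", "first", "only" and "open" are said of these compounds alone.

Of the compounds shown here, three have been measured in a functional assay on HCT-116 cells (Homo sapiens) for inhibition, read by MTT assay, with a stated time of 48 h; on this read-out lower numbers stand for stronger inhibition and higher numbers for weaker inhibition. There compound 1 `C/C=C/C(=O)N(Cc1cccc(O)c1)c1cc(OC)c(OC)c(OC)c1` gives 6700 nM, compound 2 `COc1ccc(CN(C(=O)C[Se]C#N)c2cc(OC)c(OC)c(OC)c2)cc1O` gives 310 nM, and compound 3 `C/C=C/C(=O)N(Cc1ccc(OC)c(OC)c1)c1cc(OC)c(OC)c(OC)c1` gives 32800 nM. Compound 2 therefore stands lowest of the three numbers; its nearest neighbour, compound 1, lies beyond the scatter from it, and compound 3 lies further still. Compound 4 `COc1ccc(CN(C(=O)CO)c2cc(OC)c(OC)c(OC)c2)cc1O` has not yet been measured. It differs from compound 2 in one place: one oxygen atom in place of a group of 3 heavy atoms (1 carbon, 1 nitrogen, 1 selenium; no ring), on a saturated chain carbon bound to a carbonyl carbon. Going by the values given here, no measured pair shows this same change, so the expectation rests on the three numbers alone. For compound 4 the expected step is upward and beyond the scatter, at a 19-fold higher number from compound 2 to compound 4 (1.29 log units; beyond the scatter). Compound 4 is accordingly estimated at 6000 nM, within a range from 1200 nM to 30000 nM.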

Compound 4, half-maximal inhibitory concentration: 520 nM
The estimate for compound 4 lay 12-fold (1.06 log units) above the measured number, and the stated range ends above it.
By their numbers in this assay, from the lowest: compounds 2 and 4 (each within the scatter of the next); then compound 1; then compound 3.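

In this assay, putting hydroxy in place of the group of 3 heavy atoms (1 carbon, 1 nitrogen, 1 selenium), on a saturated chain carbon bound to a carbonyl carbon, gives a 1.7-fold higher number from compound 2 to compound 4 (0.22 log units; within the scatter). At this position, then, a selenium-containing group is not needed for a number in this range, and the assay does not separate the two compounds. No measured property is at hand to account for this. Going by these compounds, whether an amine, a carboxylic acid or a longer chain at this place would give a similar number remains open.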